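This account rests on a few compounds, and the source may have more. Where it says the series, first, only, none or still open, it means among the compounds named here.

Series in a functional assay on K562 cells (Homo sapiens) for inhibition, read by sulforhodamine B assay, with a stated time of 48 h; on this read-out lower numbers stand for stronger inhibition of growth and higher numbers for weaker inhibition of growth:
- compound 1 `CCOC(=O)c1nn(-c2ccc(Cl)cc2)c(-c2ccccc2)c1CNC(C)(C)C`: 64500 nM; > 559000 nM (2 entries)
- compound 2 `CC(C)(C)NCc1c(C(=O)O)nn(-c2ccccc2)c1-c1ccc(Cl)cc1`: 364000 nM
- compound 3 `CC(C)(C)NCc1c(C(=O)O)nn(-c2ccc(Cl)cc2)c1-c1ccc(Cl)cc1`: 290000 nM

Compound 2 at 364000 nM and compound 3 at 290000 nM lie within the scatter of each other. Compound 1 offers no single number for comparison, as the disagreement in the several entries of compound 1 in this assay, 64500 nM; > 559000 nM (2 entries) shows.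

Compound 4 `CC(C)(C)NCc1c(C(=O)O)nn(-c2ccc(Cl)cc2)c1-c1ccccc1` differs from compound 3 by hydrogen in place of chloro on an aromatic carbon, or 4-chlorophenyl to phenyl. Going by the values given here, the one measured step of this kind is a 1.3-fold lower number from compound 2 to compound 3 (0.10 log units; within the scatter). It runs in the opposite sense, chloro in place of hydrogen on an aromatic carbon, at another place in the molecule, and it stays within the scatter. On that single step, no change beyond the scatter is expected in this assay, in either direction. The expected step is a 1.1-fold higher number from compound 3 to compound 4 (0.04 log units; within the scatter). For compound 4 the estimate is 320000 nM, with an expected range of 150000 nM to 650000 nM.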

Compound 4, concentration for 50% growth inhibition: > 652000 nM
Compound 4 ended at the assay's limit (the forecaster's own chance of this, stated with the estimate: 15%); at least 2.0-fold (0.30 log units) between middle value and limit.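

In this assay, hydrogen in place of chloro on this aromatic carbon, para to a large group, gives an at least 2.2-fold higher number from compound 3 to compound 4 (0.35 log units; beyond the scatter). Going by these compounds alone, this is the first step to lie beyond the scatter, whereas the chloro change at the other place in the molecule, a 1.3-fold lower number from compound 2 to compound 3 (0.10 log units; within the scatter), stays within it, so on these two steps alone the two places do not read alike. The value of compound 4, > 652000 nM, is a limit of the assay and not a number.

From the compounds shown here alone, whether a fluoro, methyl or methoxy group at this position would keep the number of compound 3 remains open. Also open is how the carboxylic acid of compound 4 compares with the ethyl ester of compound 1, which offers no single number: the several entries of compound 1 in this assay, 64500 nM; > 559000 nM (2 entries)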